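The compounds below may be only part of what the source reports. "The series", "measured", "known", "first", "only" and "open" are said of these compounds alone.

Compound 1 `COc1cc(-c2nn(-c3cccc(NC(=O)Nc4cc(C(F)(F)F)cc(C(F)(F)F)c4)c3)cc2-c2ccncc2)ccc1Cl`: 1900 nM
Compound 2 `COc1cc(-c2nn(-c3cccc(NC(=O)c4cccc(C(F)(F)F)c4)c3)cc2-c2ccncc2)ccc1Cl`: 2780 nM
Compound 3 `O=C(Nc1cccc(-n2cc(-c3ccncc3)c(-c3ccc(Cl)c(O)c3)n2)c1)Nc1cc(C(F)(F)F)cc(C(F)(F)F)c1`: 4330 nM

In a functional assay on A498 cells (Homo sapiens) for inhibition, read by sulforhodamine B assay, with a stated time of 48 h (a higher number here means a weaker inhibitor of growth, a lower number a stronger inhibitor of growth), compound 2 gives 2780 nM, the second highest of the three numbers. Compound 1 gives 1900 nM, which lies within the scatter of compound 2, and compound 3 gives 4330 nM, also within that scatter. Compound 4 `COc1cc(-c2nn(-c3cccc(NC(=O)Nc4ccc(Cl)c(C(F)(F)F)c4)c3)cc2-c2ccncc2)ccc1Cl` differs from compound 2 by (4-chloro-3-(trifluoromethyl)phenyl)amino in place of 3-(trifluoromethyl)phenyl on a carbonyl carbon. Among the compounds with values here, no measured step tests this exact change; the only step, a 2.3-fold higher number from compound 1 to compound 3 (0.36 log units; beyond the scatter), concerns a different place on the shared core. Compound 1 does carry an aryl-amino group on the same carbonyl carbon, with a different substitution, and its number sits within the scatter of compound 2. The step of a 1.3-fold lower number from compound 2 to compound 4 (0.12 log units; within the scatter) is therefore expected to stay within the scatter. Compound 4 is estimated at 2100 nM, ranging from 900 nM to 4800 nM.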

Compound 4, concentration for total growth inhibition: 6970 nM
Beside the measured number, compound 4's estimate is 3.3-fold (0.52 log units) below it, and the stated range ends below it.
By their numbers in this assay, from the lowest: compounds 1, 2, 3 and 4 (each within the scatter of the next, the first and the last beyond it).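

In this assay, within the data shown here, the change on the carbonyl carbon gives a 2.5-fold higher number from compound 2 to compound 4 (0.40 log units; beyond the scatter) and so shows that the number responds to what is attached at this position, which the earlier compounds did not test. The nitrogen and the chlorine enter together in (4-chloro-3-(trifluoromethyl)phenyl)amino, so this single step cannot assign the shift to either one. No measurement shown accounts for the step. Still open, as far as these compounds go, is how a plain phenylamino group or a cyclohexyl group on this carbonyl carbon would compare.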